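A morpholin-4-yl swap on the thiocarbonyl carbon

The source may hold more compounds than are shown below. What is called first, only, known or untested is meant among the compounds shown, and "the series" means these compounds.

In a functional assay on MGC-803 cells (Homo sapiens) for inhibition, read by MTT assay, with a stated time of 48 h (on this read-out higher numbers stand for weaker inhibition and lower numbers for stronger inhibition), compound 1 `CCN1CCN(C(=S)SCCCOc2ccc3c(=O)c(-c4ccc(OC)cc4)coc3c2)CC1` gives 54000 nM and compound 2 `COc1ccc(-c2coc3cc(OCCCSC(=S)N4CCN(c5ccccn5)CC4)ccc3c2=O)cc1` gives 42000 nM on the same scale, so the two stand level. Going by the values given here, the only measured step is a 1.3-fold lower number from compound 1 to compound 2 (0.11 log units; within the scatter) and it replaces ethyl with pyridin-2-yl on an amine nitrogen in a ring. Compound 3 `COc1ccc(-c2coc3cc(OCCCSC(=S)N4CCOCC4)ccc3c2=O)cc1` has morpholin-4-yl in place of 4-(pyridin-2-yl)piperazin-1-yl on a thiocarbonyl carbon. Among the compounds with values here, no measured compound carries morpholin-4-yl, so that one small step is the only guide, and no shift beyond the scatter is expected in this assay for this change. The expected step is a 1.1-fold higher number from compound 2 to compound 3 (0.03 log units; within the scatter) with no firm direction. Compound 3 is estimated at 45000 nM with an expected range from 20000 nM to 100000 nM on this evidence.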

Compound 3, half-maximal inhibitory concentration: 49600 nM
Beside the measured number, compound 3's estimate is 1.1-fold (0.04 log units) below it; the range from low to high includes it.
By their numbers in this assay, from the lowest: compounds 2, 3 and 1 (each within the scatter of the next).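

In this assay, morpholin-4-yl in place of 4-(pyridin-2-yl)piperazin-1-yl on the thiocarbonyl carbon gives a 1.2-fold higher number from compound 2 to compound 3 (0.07 log units; within the scatter), and in place of 4-ethylpiperazin-1-yl it gives a 1.1-fold lower number from compound 1 to compound 3 (0.04 log units; within the scatter). Among these three compounds, then, the smaller morpholin-4-yl, with its ring oxygen and no second ring nitrogen, stands level with both piperazine groups, so this swap has no measurable effect here. Nothing available explains why these numbers stand level. Still open, from the compounds shown here alone, is whether a different group on this carbon, such as a simple dimethylamino group or a piperidine carrying a carboxylic acid, would move the number beyond the scatter.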